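Fluoro to chloro on an aromatic carbon

The source may hold more compounds than are shown below. What is called first, only, known or untested is meant among the compounds shown, and "the series" means these compounds.

Measured so far in a physicochemical assay for solubility, measured as thermodynamic solubility, at pH 7.4 (on this read-out lower numbers stand for lower solubility and higher numbers for higher solubility), and shown here
Compound 1 `O=C(O)Cn1nc(Cc2nc3cc(Cl)c(OCC(F)F)cc3[nH]2)c2ccccc2c1=O` gives > 1000 ug/mL as a limit of the assay, not a number
Compound 2 `CCOc1cc2[nH]c(Cc3nn(CC(=O)O)c(=O)c4ccccc34)nc2cc1Cl` gives 917 ug/mL as a number
Compound 3 `O=C(O)Cn1nc(Cc2nc3cc(F)c(OCC4CC4)cc3[nH]2)c2ccccc2c1=O` gives 841 ug/mL as a number

Compound 3 at 841 ug/mL and compound 2 at 917 ug/mL lie within the scatter of each other. Compound 4 `O=C(O)Cn1nc(Cc2nc3cc(Cl)c(OCC4CC4)cc3[nH]2)c2ccccc2c1=O` differs from compound 3 in one place chloro in place of fluoro on an aromatic carbon and carries chloro in place of fluoro on an aromatic carbon. Going by the values given here, the only measured step of an at least 1.0-fold lower number from compound 1 to compound 2 (0.03 log units; that floor lies within the scatter) has a floor within the scatter and concerns a different place, so it bears only loosely. Among the compounds with values here, no measured step makes this exchange, so no shift beyond the scatter is expected in this assay and no firm direction. The estimated step of a 1.1-fold lower number from compound 3 to compound 4 (0.03 log units; within the scatter) stays within the scatter. The estimate for compound 4 is 780 ug/mL with an expected range from 400 ug/mL to 1300 ug/mL in this measurement.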

Compound 4, solubility: 395 ug/mL
Beside the measured number, compound 4's estimate is 2.0-fold (0.30 log units) above it, outside the stated range (below it).
By their numbers in this assay, from the lowest: compound 4; then compounds 3 and 2 (each within the scatter of the next). At a limit, above all of these: compound 1.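

In this assay, the aromatic carbon ortho to a cyclopropylmethoxy group proves sensitive to the halogen it carries: chloro in place of fluoro gives a 2.1-fold lower number from compound 3 to compound 4 (0.33 log units; beyond the scatter). With chloro held fixed, the chain on the oxygen matters too: cyclopropyl in place of methyl gives a 2.3-fold lower number from compound 2 to compound 4 (0.37 log units; beyond the scatter), and cyclopropyl in place of difluoromethyl gives an at least 2.5-fold lower number from compound 1 to compound 4 (0.40 log units; beyond the scatter). That last step is only a floor, as compound 1 carries a limit and not a number: the limit of > 1000 ug/mL in this assay, at which 1 of the 4 values shown sits.

Still open, on these data alone, is whether the halogen exchange acts alike with other chains on the oxygen. Also open, as far as these compounds go, is where bromo, a nitrile or an amine on this aromatic carbon would fall.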